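The compounds below may be only part of what the source reports. "The series", "measured", "known", "first", "only" and "open" are said of these compounds alone.

Measured compounds:
compound 1 `O=C(CN1CCN(C(=O)c2cccc(F)c2)CC1)N1CCN(CCCc2c[nH]c3ccccc23)CC1`: 165000 nM
compound 2 `O=C(CN1CCN(C(=O)c2ccccc2)CC1)N1CCN(CCCc2c[nH]c3ccc(F)cc23)CC1`: 146000 nM

Both numbers come from an ADME assay on SH-SY5Y cells (Homo sapiens) for cytotoxicity, read by MTT assay, with a stated time of 72 h; on this read-out lower numbers stand for stronger inhibition and higher numbers for weaker inhibition. In this assay compound 2 gives 146000 nM, and compound 1 gives 165000 nM. These two values lie within the scatter of each other, so neither compound can be placed above the other; the pair simply marks the level at which this series sits. Among the measured compounds shown here, no step between compounds that differ in one place is on record, so that level is the only guide for a new compound.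

Compound 3 `O=C(CN1CCN(C(=O)c2ccccc2Br)CC1)N1CCN(CCCc2c[nH]c3ccc(F)cc23)CC1` is not yet measured. It differs from compound 2 by bromo in place of hydrogen on an aromatic carbon. Nothing in the pair shows what such a change does in this assay. The expected step, a 1.2-fold lower number from compound 2 to compound 3 (0.09 log units; within the scatter), is therefore one of no more than the scatter, in either direction. The estimate for compound 3 in this assay is 120000 nM, with a range from 50000 nM to 300000 nM.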

Compound 3, half-maximal inhibitory concentration: 79100 nM
Compound 3: the middle estimate sits 1.5-fold (0.18 log units) above what was measured; low and high end bracket the measured number.
By their numbers in this assay, from the lowest: compounds 3, 2 and 1 (each within the scatter of the next, the first and the last beyond it).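

Bromo in place of hydrogen on an aromatic carbon, ortho to a large group, gives a 1.8-fold lower number from compound 2 to compound 3 (0.27 log units; within the scatter) in this assay, the only one-place step that can be read among the compounds shown. Phenyl to 2-bromophenyl therefore stays within the scatter on this read-out, and this single heavy atom at this place does not separate the two compounds. No other data bear on this step.

Still open, going by these compounds, is whether chloro, a methoxy group, an amine or a carboxylic acid at the same place would give a step beyond the scatter. Also open, on these data alone, is whether bromo at the other aromatic carbons of this six-membered ring would give a step of similar size.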